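The source may hold more compounds than are shown below. What is called first, only, known or untested is meant among the compounds shown, and "the series" means these compounds.

Measured so far:
compound 1, `Cc1ccccc1-n1nncc1CN1C(=O)C2(C(C#N)=C(N)Oc3c2c2nc4ccccc4nc2c2ccccc32)c2ccccc21`: > 50000 nM
compound 2, `CCc1ccccc1-n1nncc1CN1C(=O)C2(C(C#N)=C(N)Oc3c(N)cc4nc5ccccc5nc4c32)c2ccccc21`: 17900 nM

In a functional assay on HepG2 cells (Homo sapiens) for antiproliferative activity, read by MTT assay, with a stated time of 48 h (a higher number here means a weaker inhibitor, a lower number a stronger inhibitor), compound 1 reaches only the limit of the assay, > 50000 nM, and gives no number. For the measured compounds named here, compound 2 is the one compound with a measured number in this assay, 17900 nM. Going by the values given here, the only other value shown for the set is the limit reached by compound 1, (the limit of > 50000 nM in this assay, at which 1 of the 2 values shown sits). Among the compounds with values here, no two measured compounds differ in a single place, so there is no measured step to set a scale for what a change of this kind does.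

Compound 3, `COc1ccc(OC)c(-n2nncc2CN2C(=O)C3(C(C#N)=C(N)Oc4c(N)cc5nc6ccccc6nc5c43)c3ccccc32)c1`, has not yet been measured. It differs from compound 2 as follows: 2,5-dimethoxyphenyl in place of 2-ethylphenyl on an aromatic nitrogen. Within the data shown here, with no measured step to lean on, the step that the estimate means is a 1.1-fold higher number from compound 2 to compound 3 (0.05 log units; within the scatter), and it is expected to lie within the usual scatter of this assay, in neither direction. Compound 3 is therefore expected to give about 20000 nM in this assay, with a range from 7000 nM to 50000 nM. Because compound 2 sits at 17900 nM, a weak value, the estimate for compound 3 also leaves a fair chance that the assay reports no number for it.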

Compound 3, half-maximal inhibitory concentration: 45100 nM
Compound 3: middle estimate off by 2.3-fold (0.35 log units), on the low side, within the range that was stated.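

For the compounds shown here, the change from 2-ethylphenyl to 2,5-dimethoxyphenyl on the aromatic nitrogen gives a 2.5-fold higher number from compound 2 to compound 3 (0.40 log units; beyond the scatter) in this assay, the first measured step in this set, and it shows that the group at this position can move the read-out. The step is modest and points towards a weaker inhibitor, but it rests on this one pair, in which the ethyl group leaves and the methoxy groups enter together, so the pair cannot say which of these accounts for the shift. Compound 1 remains the only compound at the limit of the assay, and its entry is a limit rather than a number: the limit of > 50000 nM in this assay, at which 1 of the 3 values shown sits.

The compounds shown leave open whether either methoxy group alone would give the same step, as a 2-methoxyphenyl or a 3-methoxyphenyl group at this position could show. They also leave open whether a plain phenyl group, or a phenyl group carrying an amine or a carboxylic acid, would give a lower or a higher number than compound 2 does, at 17900 nM.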